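Removing the Ester Chain from a Selenium-Bearing Series

The source may report more compounds than this note shows. Statements on the series, on what has been measured and on what is new or still open speak of the compounds shown alone.

Measured so far in a functional assay on RKO cells (Homo sapiens) for inhibition, read by MTT assay, with a stated time of 48 h; on this read-out lower numbers stand for stronger inhibition and higher numbers for weaker inhibition
- Compound 1 `COc1ccc(N(C)c2nc(C)nc3ccccc23)cc1C(=O)OCC[Se]C#N` gives 2390 nM
- Compound 2 `COc1ccc(N(C)c2nc(C)nc3ccccc23)cc1C(=O)OCCC[Se]C#N` gives 1140 nM
- Compound 3 `COc1ccc(N(C)c2nc(C)nc3ccccc23)cc1C(=O)OCCCC[Se]C#N` gives 1020 nM

Lengthening the chain first gave a 2.1-fold lower number from compound 1 to compound 2 (0.32 log units; beyond the scatter), and across the series it gave a 2.3-fold lower number from compound 1 to compound 3 (0.37 log units; beyond the scatter), but the last extension gave only a 1.1-fold lower number from compound 2 to compound 3 (0.05 log units; within the scatter). Compound 3 therefore stands level with compound 2 and clearly lower than compound 1.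

The next change, to compound 4 `COc1ccc(N(C)c2nc(C)nc3ccccc23)cc1[Se]C#N`, is of another kind: a group of 3 heavy atoms (1 carbon, 1 nitrogen, 1 selenium; no ring) in place of a group of 10 heavy atoms (6 carbon, 1 nitrogen, 2 oxygen, 1 selenium; no ring), on an aromatic carbon, on an aromatic carbon, ortho to a methoxy group. Within the data shown here, no measured step removes the whole chain, so the three steps bear on this change only weakly. Going by these compounds, the shortest chain, in compound 1 at 2390 nM, lies only modestly above the others, so a large jump is not expected, and the direction remains open. The expected change, a rough estimate, is a 1.5-fold lower number from compound 3 to compound 4 (0.16 log units; within the scatter). Compound 4 is estimated at 700 nM, with an expected range from 80 nM to 3500 nM.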

Compound 4, half-maximal inhibitory concentration: 47 nM
The estimate for compound 4 lay 15-fold (1.17 log units) above the measured number, and the stated range ends above it.
By their numbers in this assay, from the lowest: compound 4; then compounds 3 and 2 (each within the scatter of the next); then compound 1.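

In this assay, the group of 3 heavy atoms placed directly on the aromatic carbon, ortho to a methoxy group, in place of the whole ester chain, gives a far larger change (a 22-fold lower number from compound 3 to compound 4 (1.34 log units; beyond the scatter)) than any change in chain length had given. The drop is just as clear against the two shorter chains (a 24-fold lower number from compound 2 to compound 4 (1.38 log units; beyond the scatter); a 51-fold lower number from compound 1 to compound 4 (1.71 log units; beyond the scatter)). This position therefore responds much more strongly to removing the chain than to altering its length, and compound 4 stands lowest of the four, beyond the scatter of each of the others.

Nothing at hand explains the size of this drop. Still open, going by these compounds, is whether a single methylene carbon between the ring and the selenium, or an amide in place of the ester, would keep so low a number.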